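From Nitro to Hydroxy: Estimating Compound 3

The compounds below may be only part of what the source reports. "The series", "measured", "known", "first", "only" and "open" are said of these compounds alone.

Values so far in a functional assay on KB cells (Homo sapiens) for antiproliferative activity, read by MTT assay, with a stated time of 72 h; a higher number here means a weaker inhibitor, a lower number a stronger inhibitor
- Compound 1 `CCOC(=O)c1cc(-c2cc(OC)c(OC)c(OC)c2)c(-c2ccc(OC)c([N+](=O)[O-])c2)s1` gives 15800 nM
- Compound 2 `COc1ccc(-c2sc(C(=O)O)cc2-c2cc(OC)c(OC)c(OC)c2)cc1[N+](=O)[O-]` gives 35900 nM

Of these two, compound 2 has the higher number (35900 nM), which makes it the weaker inhibitor. Compound 3 `COc1ccc(-c2sc(C(=O)O)cc2-c2cc(OC)c(OC)c(OC)c2)cc1O` differs from compound 2 in one group: hydroxy in place of nitro on an aromatic carbon, ortho to a methoxy group (hydroxy in place of nitro on an aromatic carbon). Within the data shown here, only one measured step exists, a 2.3-fold higher number from compound 1 to compound 2 (0.36 log units; beyond the scatter), and it swaps ethyl for hydrogen at a different place. Among the measured compounds shown here, no measured step touches the nitro group, so the data give no direction for this change and only a rough sense of size. A modest step toward a lower number in this assay is nevertheless expected, held loosely. The expected change is a 3.0-fold lower number from compound 2 to compound 3 (0.48 log units; beyond the scatter), and it remains an estimate. For compound 3 the estimated value is 12000 nM (expected range 1500 nM to 50000 nM).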

Compound 3, half-maximal inhibitory concentration: 11200 nM
Estimate against measurement, compound 3: 1.1-fold (0.03 log units) above; measured number inside the range.
By their numbers in this assay, from the lowest: compounds 3 and 1 (each within the scatter of the next); then compound 2.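

In this assay, among these compounds, the aromatic position ortho to a methoxy group proves sensitive to what it carries: hydroxy in place of nitro gives a 3.2-fold lower number from compound 2 to compound 3 (0.51 log units; beyond the scatter) and is the first measured change at this position. Nitro has no hydrogen-bond donor and hydroxy has one, and hydroxy is also the smaller group, so the lower number comes with both differences at once and this single step cannot separate them. Nothing measured here accounts for the shift.

The compounds shown leave open whether an amine or a fluorine at this position would move the number in the same direction as hydroxy. They also leave open whether the same swap would give a similar step in the ethyl ester series, where compound 1 still carries the nitro group.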